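The source may hold more compounds than are shown below. What is called first, only, known or untested is meant among the compounds shown, and "the series" means these compounds.

In a functional assay on SGC-7901 cells (Homo sapiens) for antiproliferative activity, read by sulforhodamine B assay, with a stated time of 72 h (a lower number here means a stronger inhibitor, a higher number a weaker inhibitor), compound 3 `Cc1ccccc1NC(=S)N/N=C/c1ccc2ccccc2n1` gives > 100000 nM, which is a limit of the assay and not a number. Compound 1 `Fc1ccccc1NC(=S)N/N=C/c1ccc2ccccc2n1` gives > 100000 nM, also a limit. Going by the values given here, compound 2 `S=C(NCc1ccccc1)N/N=C/c1ccc2ccccc2n1` gives 53700 nM, the only true number so far. Compound 3 therefore stands at the limit of > 100000 nM in this assay, at which 2 of the 3 values shown sit.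

The next compound, compound 4 `Fc1cccc(NC(=S)N/N=C/c2ccc3ccccc3n2)c1`, keeps the shared core and carries 3-fluorophenyl in place of 2-methylphenyl on an amide-type nitrogen. Among the compounds with values here, three measured steps bear on this change. Benzyl in place of 2-fluorophenyl gives an at least 1.8-fold lower number from compound 1 to compound 2 (0.27 log units; that floor lies within the scatter), and 2-methylphenyl in place of benzyl gives an at least 1.8-fold higher number from compound 2 to compound 3 (0.27 log units; that floor lies within the scatter). Both floors lie within the scatter. Methyl in place of fluoro gives a step that the two limits leave unreadable from compound 1 to compound 3, so that step has no readable size. The closest guide is compound 1, the 2-fluorophenyl relative, whose > 100000 nM is likewise a limit. No step beyond the scatter is therefore expected, and this assay may well report only a limit again. The expected change is an at least 1.2-fold lower number from compound 3 to compound 4 (0.09 log units; that floor lies within the scatter). For compound 4 the estimated value is 80000 nM, with an expected range from 30000 nM to 150000 nM.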

Compound 4, half-maximal inhibitory concentration: 79900 nM
Compound 4: middle estimate off by 1.0-fold (0.00 log units), on the high side; the range from low to high includes it.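

In this assay, compound 4 gives this amide-type nitrogen its first true number with a phenyl ring attached directly, whereas compound 1 and compound 3 each remain a limit of the assay and not a number: the limit of > 100000 nM in this assay, at which 2 of the 4 values shown sit. Set against those two limits, 3-fluorophenyl gives an at least 1.2-fold lower number from compound 3 to compound 4 (0.09 log units; that floor lies within the scatter) and an at least 1.2-fold lower number from compound 1 to compound 4 (0.09 log units; that floor lies within the scatter), and neither floor clears the scatter. Set against benzyl, it gives a 1.5-fold higher number from compound 2 to compound 4 (0.17 log units; within the scatter), so 3-fluorophenyl and benzyl cannot be told apart here, and no group shown at this position has yet produced a step beyond the scatter.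

Going by these compounds, since compound 1 carries only a limit, the comparison between 2-fluorophenyl and 3-fluorophenyl fixes no size, and the effect of where the fluorine sits on the ring stays open. On these data alone, it also remains open whether a longer chain such as phenethyl, or a phenyl ring bearing a carboxylic acid or an amine, would move the number on this nitrogen beyond the scatter.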